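The compounds below may be only part of what the source reports. "The series", "measured", "known", "first", "only" and "open" are said of these compounds alone.

Of the compounds shown here, three built on a shared core have been tested in a functional assay on A549 cells (Homo sapiens) for antiproliferative activity, read by MTT assay, with a stated time of 24 h; a higher number here means a weaker inhibitor, a lower number a stronger inhibitor. In this assay compound 1 `Cc1ccccc1NNC(=O)c1ccc(NS(=O)(=O)c2cnc(O)nc2O)cc1` gives 14500 nM. In the same test, compound 2 `O=C(NNc1cccc(Cl)c1)c1cccc(NS(=O)(=O)c2cnc(O)nc2O)c1` gives 6640 nM, the lower of the two numbers available, and the gap between them lies beyond the usual scatter. Compound 3 `Cc1ccccc1NNC(=O)c1ccccc1NS(=O)(=O)c1cnc(O)nc1O` yields no number, only a limit of > 20000 nM. Compound 2 therefore stands as the strongest inhibitor of the measured set.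

The next compound to be considered is compound 4 `O=C(NNC(=O)c1ccccc1F)c1cccc(NS(=O)(=O)c2cnc(O)nc2O)c1`, which has not yet been measured. It departs from compound 2 on an amine nitrogen, where (2-fluorophenyl)carbonyl takes the place of 3-chlorophenyl: (2-fluorophenyl)carbonyl in place of 3-chlorophenyl on an amine nitrogen. For the measured compounds named here, none of the measured pairs shows this change, so there is no direct precedent for its size. Compound 2, at 6640 nM, sets the starting point, and compound 1, at 14500 nM, shows how readily a number in this series can lie higher. A modest weakening is therefore expected, with the estimated change being a 1.8-fold higher number from compound 2 to compound 4 (0.26 log units; within the scatter). For compound 4 the estimated value is 12000 nM, with an expected range from 5000 nM to 28000 nM.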

Compound 4, half-maximal inhibitory concentration: 10800 nM
Compound 4: the middle estimate sits 1.1-fold (0.05 log units) above what was measured; low and high end bracket the measured number.
By their numbers in this assay, from the lowest: compounds 2, 4 and 1 (each within the scatter of the next, the first and the last beyond it). At a limit, above all of these: compound 3.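

In this assay, for the compounds shown here, the exchange of 3-chlorophenyl for (2-fluorophenyl)carbonyl on this amine nitrogen gives the first step that can be read at a single place, and it comes to a 1.6-fold higher number from compound 2 to compound 4 (0.21 log units; within the scatter) with no order to be drawn between the two compounds. The earlier compounds shown here could not show that this place accepts a change from (3-chlorophenyl)amino to ((2-fluorophenyl)carbonyl)amino, which adds a carbonyl and a hydrogen-bond acceptor, while the number stays within the scatter. Nothing in the data on hand accounts for the size of this step.

From the compounds shown here alone, this one step alters the carbonyl, the halogen and its printed position together, so their separate shares remain unknown, as does whether another group on this nitrogen, such as a simple methyl group, a longer alkyl chain, an amine or a carboxylic acid, would move the number beyond the scatter. Compound 3 remains a limit at > 20000 nM and not a number, and it has no single-place step to any other compound shown.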